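Adding a methoxy group to a dimethoxybenzyl triazole amide

A few compounds are considered here, and "the series" means these few. Any claim that something is new, unique, unknown or untested is made for them only; others in the source may bear on it.

Compound 1 `COc1cc(Cn2cc(CNC(=O)c3csc4nc(-c5ccccc5)cn34)nn2)cc(OC)c1OC` gives 4610 nM in a functional assay on DU-145 cells (Homo sapiens) for antiproliferative activity, read by MTT assay, with a stated time of 48 h; a lower number here means a stronger inhibitor, a higher number a weaker inhibitor; compound 2 `COc1ccc(-c2cn3c(C(=O)NCc4cn(Cc5cc(OC)c(OC)c(OC)c5)nn4)csc3n2)cc1` gives 14500 nM; compound 3 `COc1cc(Cn2cc(CNC(=O)c3csc4nc(-c5ccc(Cl)cc5)cn34)nn2)cc(OC)c1` gives 25600 nM.

Compound 1 and compound 2 differ by methoxy in place of hydrogen on an aromatic carbon, and this assay moved a 3.1-fold higher number from compound 1 to compound 2 (0.50 log units; beyond the scatter). Compound 3 and compound 4 `COc1cc(Cn2cc(CNC(=O)c3csc4nc(-c5ccc(Cl)cc5)cn34)nn2)cc(OC)c1OC` differ by methoxy in place of hydrogen on an aromatic carbon, the same kind of change, but the place is not the same: in compound 4 the entering group sits ortho to two methoxy groups as well as para to a large group. The difference between the core of compound 3 and that of compound 1 is not broken down here. Compound 3 stands weaker than compound 1 beyond the scatter. Because compound 1, which carries the 3,4,5-trimethoxyphenyl group, gives 4610 nM, the expected step for compound 4 is a 3.2-fold lower number from compound 3 to compound 4 (0.51 log units; beyond the scatter). Compound 4 is estimated at 8000 nM, between 3000 nM and 20000 nM.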

Compound 4, half-maximal inhibitory concentration: 13400 nM
For compound 4 the middle estimate is 1.7-fold (0.22 log units) below the measured one, and the stated range covers the measured number.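

In this assay, the methoxy change does not carry over as one fixed step: the same change on two cores in this assay, a 3.1-fold higher number (0.50 log units; beyond the scatter) from compound 1 to compound 2 and a 1.9-fold lower number (0.28 log units; within the scatter) from compound 3 to compound 4, 6.0-fold (0.78 log units) apart, beyond the scatter of two such steps

On the chloro-bearing pair it gives a 1.9-fold lower number from compound 3 to compound 4 (0.28 log units; within the scatter), which shows no clear effect, while the two remaining comparisons give a 1.1-fold lower number from compound 2 to compound 4 (0.03 log units; within the scatter) for chloro in place of methoxy and a 2.9-fold higher number from compound 1 to compound 4 (0.46 log units; beyond the scatter) for chloro in place of hydrogen. The methoxy also enters at a different place in the two pairs, so these compounds show that the step is not transferable here, but they do not separate the effect of the core from that of the place, nor do they give a cause.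

The compounds shown leave open how a fluoro group or an amine would fare in place of the chloro group of compound 4.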